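The source may report more compounds than this note shows. Statements on the series, on what has been measured and on what is new or still open speak of the compounds shown alone.

Measured in a functional assay on CCRF-CEM cells (Homo sapiens) for inhibition, read by MTT assay, with a stated time of 2 days, tested at 10 uM; on this read-out higher numbers stand for more inhibition at the one concentration tested (going by the name of the read-out) and lower numbers for less inhibition:
compound 1 `COc1ccc(OC)c(-c2cn(-c3ccc(O)c(C(=O)Nc4cccc(C(F)(F)F)c4)c3)nn2)c1`: 15%
compound 2 `COc1ccccc1-c1cn(-c2ccc(O)c(C(=O)Nc3cccc(C(F)(F)F)c3)c2)nn1`: 65%
compound 3 `COc1ccc(-c2cn(-c3ccc(O)c(C(=O)Nc4cccc(C(F)(F)F)c4)c3)nn2)cc1`: 12%

Compound 2 stands highest of the three numbers in this assay; both steps to it, a number 50 percentage points higher from compound 1 to compound 2 (beyond the scatter) and a number 53 percentage points lower from compound 2 to compound 3 (beyond the scatter), lie beyond the scatter, whereas a number 3 percentage points lower from compound 1 to compound 3 (within the scatter) lies within it.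

Compound 4 `COc1ccccc1-c1cn(-c2ccc(O)c(C(=O)OCCCc3ccccc3)c2)nn1` differs from compound 2 by 3-phenylpropoxy in place of (3-(trifluoromethyl)phenyl)amino on a carbonyl carbon. Going by the values given here, none of the measured steps bears on that carbonyl carbon: all three concern the methoxyphenyl group only, so there is no direct precedent for exchanging the amide for an ester. Among the compounds with values here, the expectation therefore rests on compound 2 alone and is uncertain, with a loss of the single hydrogen-bond donor counted above as the only guide. For compound 4 a value of 40% is estimated, within 10% to 70%, which means an expected step of a number 25 percentage points lower from compound 2 to compound 4 (beyond the scatter).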

Compound 4, a percentage reported as inhibition, at one concentration (the size of the read-out at that concentration, not a potency): 4%
Beside the measured number, compound 4's estimate is 36 percentage points above it; measured number outside the range, below it.
By their numbers in this assay, from the lowest: compounds 4, 3 and 1 (each within the scatter of the next, the first and the last beyond it); then compound 2.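

In this assay the carbonyl carbon proves a second sensitive place besides the methoxyphenyl group, with a number 61 percentage points lower from compound 2 to compound 4 (beyond the scatter) when 3-phenylpropoxy replaces (3-(trifluoromethyl)phenyl)amino. The 2-methoxyphenyl group of compound 2 therefore does not hold up the read-out on its own. Nothing at hand gives a reason for this loss.

The change swaps the amide link and the aryl group together, so the compounds shown do not separate the two. A 3-phenylpropylamino group or a carboxylic acid on that carbonyl carbon would bear on this.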